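Nitrophenyl amide in place of hydroxyphenyl amide

This account rests on a few compounds, and the source may have more. Where it says the series, first, only, none or still open, it means among the compounds named here.

Measured compounds in a functional assay on HCT-116 cells (Homo sapiens) for cytotoxicity, read by MTT assay; on this read-out lower numbers stand for stronger inhibition and higher numbers for weaker inhibition:
- compound 1 `CCn1cc(-c2nc3ccc([N+](=O)[O-])cc3o2)c(=O)c2cc(F)c(N3CCNC(C)C3)c(F)c21`: compound 1 gives 1100 nM
- compound 2 `CCn1cc(C(=O)Nc2ccccc2O)c(=O)c2cc(F)c(N3CCNC(C)C3)c(F)c21`: compound 2 gives 5370 nM
- compound 3 `CCn1cc(C(=O)Nc2ccc(Cl)cn2)c(=O)c2cc(F)c(N3CCNC(C)C3)c(F)c21`: compound 3 gives 3300 nM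

Compound 2 has the highest of the three numbers; compound 3 sits nearest, compound 1 furthest.

Compound 4 `CCn1cc(C(=O)Nc2cccc([N+](=O)[O-])c2)c(=O)c2cc(F)c(N3CCNC(C)C3)c(F)c21` is not yet measured. It differs from compound 2 by 3-nitrophenyl in place of 2-hydroxyphenyl on an amide-type nitrogen.

For the measured compounds named here, the only measured step at the same place is a 1.6-fold lower number from compound 2 to compound 3 (0.21 log units; within the scatter). Going by the values given here, compound 1 carries a nitro group as well, but no single-point step links it to compound 2, and its number is simply the lowest of the three. For compound 4 the expectation in this assay is therefore a step about like a 1.5-fold lower number from compound 2 to compound 4 (0.19 log units; within the scatter), staying close to compound 2 and compound 3. Compound 4 is estimated at 3500 nM, within 1200 nM to 10000 nM.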

Compound 4, half-maximal inhibitory concentration: 2710 nM
Estimate against measurement, compound 4: 1.3-fold (0.11 log units) above, within the range that was stated.
By their numbers in this assay, from the lowest: compound 1; then compounds 4, 3 and 2 (each within the scatter of the next).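

In this assay the amide-type nitrogen accepts 3-nitrophenyl with a 2.0-fold lower number from compound 2 to compound 4 (0.30 log units; within the scatter) and with a 1.2-fold lower number from compound 3 to compound 4 (0.09 log units; within the scatter) as well, so all three groups at this position remain within the scatter of their listed neighbours. Replacing 2-hydroxyphenyl, with its hydrogen-bond donor, by 3-nitrophenyl, with none, therefore gives no step beyond the scatter in these compounds. No supporting measurement bears on the reason for this result.

Still open, on these data alone, is whether an aminophenyl or carboxyphenyl group, or a longer alkyl chain in place of the aromatic ring, would move the number beyond the scatter.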